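The compounds below may be only part of what the source reports. "The series", "measured", "known", "first", "only" and "open" are said of these compounds alone.

Compound 3 `O=C(Nc1ccc(Sc2nc3ccccc3s2)cc1)c1ccccc1O` carries a 2-hydroxyphenyl on the carbonyl carbon of its amide. In an assay for inhibition of HSP60/HSP10 (Homo sapiens), with a stated time of 60 min (on this read-out higher numbers stand for weaker inhibition and lower numbers for stronger inhibition), compound 3 gives > 100000 nM, which is a limit of the assay and not a number. Compound 1 `O=C(Nc1ccc(Sc2nc3ccccc3s2)cc1)c1cc(Br)cc(Br)c1O` has 3,5-dibromo-2-hydroxyphenyl in place of that group, and in this assay compound 1 gives 4700 nM. The step of an at least 21-fold higher number from compound 1 to compound 3 (1.32 log units; beyond the scatter) accompanies the loss of the bromines. Compound 2 `O=C(Nc1ccc(Sc2nc3ccccc3s2)c(Cl)c1)c1ccccc1O` carries a chloro on an aromatic carbon that is hydrogen in compound 3. In this assay compound 2 gives > 100000 nM, again a limit of the assay and not a number. The step that the two limits leave unreadable from compound 2 to compound 3 cannot be sized because both ends sit at the limit of > 100000 nM in this assay, at which 2 of the 3 values shown sit.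

Compound 4 `COc1ccccc1C(=O)Nc1ccc(Sc2nc3ccccc3s2)cc1` differs from compound 3 by methyl in place of hydrogen on an oxygen on an aromatic ring. Neither measured step touches the hydroxy on this ring, so no direct guide exists; the only movement seen, from compound 1, ran toward the limit. For compound 4 a result at or past the limit is expected, with a step that the limit leaves unreadable from compound 3 to compound 4 as the implied step, its size unreadable from a limit. Compound 4 is estimated at 150000 nM, within 50000 nM to 500000 nM.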

Compound 4, half-maximal inhibitory concentration: > 100000 nM
Compound 4: no number, only a limit; the forecaster's own chance of this, stated with the estimate: 85%; the middle value is on the limit's open side.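

With methyl in place of hydrogen on the oxygen, compound 4 gives > 100000 nM in this assay, which is a limit of the assay and not a number. Set against the brominated compound, the change reads as an at least 21-fold higher number from compound 1 to compound 4 (1.32 log units; beyond the scatter), but that step removes the bromines and adds the methyl together, so it cannot be credited to the methyl alone. The effect of the methyl by itself cannot be read, because both compounds of that pair sit at the same ceiling: the limit of > 100000 nM in this assay, at which 3 of the 4 values shown sit.

The compounds shown leave open what a methyl on this oxygen would do on the 3,5-dibromo-2-hydroxyphenyl group, where there is a real number to move from. Also open, on these data alone, is whether a single bromine, or an amine in place of the bromines, would bring the 2-hydroxyphenyl series off the limit.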